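Furan-3-yl in Place of Thiophen-2-yl on a Nucleoside Core

The source may hold more compounds than are shown below. What is called first, only, known or untested is meant among the compounds shown, and "the series" means these compounds.

Measured compounds:
compound 1 `C#Cc1cn([C@@H]2O[C@H](CO)[C@@H](O)[C@H]2O)c2ncnc(N(C)C)c12`: 260 nM
compound 2 `Cc1nc(N)c2c(-c3cccs3)cn([C@@H]3O[C@H](CO)[C@@H](O)[C@H]3O)c2n1`: > 20000 nM
compound 3 `COc1ncnc2c1c(-c1ccccc1)cn2[C@@H]1O[C@H](CO)[C@@H](O)[C@H]1O`: > 20000 nM

In a functional assay on K562 cells (Homo sapiens), read by MTT assay, with a stated time of 72 h (on this read-out higher numbers stand for weaker inhibition and lower numbers for stronger inhibition), compound 1 gives 260 nM. For compound 2 the value > 20000 nM is a limit of this assay and not a number. For compound 3 the value > 20000 nM is likewise a limit. Compound 2 thus sits where (the limit of > 20000 nM in this assay, at which 2 of the 3 values shown sit).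

Compound 4 `Cc1nc(N)c2c(-c3ccoc3)cn([C@@H]3O[C@H](CO)[C@@H](O)[C@H]3O)c2n1` differs from compound 2 in one place: furan-3-yl in place of thiophen-2-yl on an aromatic carbon. Among the compounds with values here, no step between measured compounds is at hand, so the size of the change cannot be read from the data. Compound 4 is expected to stay near the limit, a step from compound 2 of a step that the limit leaves unreadable from compound 2 to compound 4, not beyond the scatter. Compound 4 is estimated at 25000 nM, within 8000 nM to 80000 nM.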

Compound 4, half-maximal inhibitory concentration: > 20000 nM
Compound 4: no number, only a limit; the forecaster's own chance of this, stated with the estimate: 75%; the middle value is on the limit's open side.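

No step can be read from compound 2 to compound 4, as each carries only a limit and not a number: the limit of > 20000 nM in this assay, at which 3 of the 4 values shown sit.

The compounds shown leave open whether furan-3-yl and thiophen-2-yl on the shared core differ in activity at all.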